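Furan-2-yl in place of pyridin-3-yl on the pyridine core

This account rests on a few compounds, and the source may have more. Where it says the series, first, only, none or still open, it means among the compounds named here.

Measured so far:
compound 1, `Oc1cccc(-c2cc(-c3ccc(Cl)cc3)nc(-c3ccco3)c2)c1`, 11400 nM
compound 2, `Oc1cccc(-c2cc(-c3ccsc3)nc(-c3cccc(Cl)c3)c2)c1`, 3330 nM
compound 3, `Oc1cccc(-c2cc(-c3cccnc3)nc(-c3cccc(Cl)c3)c2)c1`, "not determined" (no result reported)

In a functional assay on DU-145 cells (Homo sapiens) for cytotoxicity, read by CCK-8 assay and cell counting, with a stated time of 2 days (on this read-out lower numbers stand for stronger inhibition and higher numbers for weaker inhibition), compound 1 gives 11400 nM and compound 2 gives 3330 nM; these two values are what the series shows so far. For compound 3 this assay records "not determined" (no result reported), so no single number stands for it and it cannot be placed against the others. Compound 4, `Oc1cccc(-c2cc(-c3cccc(Cl)c3)nc(-c3ccco3)c2)c1`, differs from compound 3 by furan-2-yl in place of pyridin-3-yl on an aromatic carbon. With no value for compound 3, the size and direction of the step to compound 4 in this assay cannot be set; it is expected to lie somewhere in the band spanned by compound 1 and compound 2. Compound 4 is estimated at 7000 nM, with a range from 2500 nM to 20000 nM.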

Compound 4, half-maximal inhibitory concentration: 2020 nM
Compound 4: the middle estimate sits 3.5-fold (0.54 log units) above what was measured; measured number below the stated range.
By their numbers in this assay, from the lowest: compounds 4 and 2 (each within the scatter of the next); then compound 1.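

With furan-2-yl held, 3-chlorophenyl in place of 4-chlorophenyl gives a 5.6-fold lower number from compound 1 to compound 4 (0.75 log units; beyond the scatter) in this assay, so the site of the chlorine on the phenyl group registers in this read-out. With 3-chlorophenyl held, furan-2-yl in place of thiophen-3-yl gives a 1.6-fold lower number from compound 2 to compound 4 (0.22 log units; within the scatter), so the two five-membered aromatic rings are not told apart here. No evidence at hand accounts for either step.

The step from pyridin-3-yl to furan-2-yl cannot be read, as compound 3 has no number. On these data alone, whether an amine or a carboxylic acid on this aromatic carbon would be tolerated remains open.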